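The source may hold more compounds than are shown below. What is called first, only, known or untested is meant among the compounds shown, and "the series" means these compounds.

Measured in a functional assay on HeLa cells (Homo sapiens) for cytotoxicity, read by sulforhodamine B assay; on this read-out lower numbers stand for stronger inhibition and higher numbers for weaker inhibition:
- compound 1 `Cc1ccccc1S(=O)(=O)NC(C1=CC(=O)c2c(O)ccc(O)c2C1=O)C(C)C`: 790 nM
- compound 2 `CC(C)C(NS(=O)(=O)c1ccccc1Br)C1=CC(=O)c2c(O)ccc(O)c2C1=O`: 8310 nM

Compound 2 has the higher of these two numbers, so it is the weaker inhibitor of the pair. The next compound, compound 3 `CCOC(=O)c1ccc(S(=O)(=O)NC(C2=CC(=O)c3c(O)ccc(O)c3C2=O)C(C)C)cc1`, differs from it only in the group on the sulfonyl sulfur, where 4-(ethoxycarbonyl)phenyl stands in place of 2-bromophenyl: 4-(ethoxycarbonyl)phenyl in place of 2-bromophenyl on a sulfonyl sulfur.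

For the measured compounds named here, only one measured step bears on this change: an 11-fold higher number from compound 1 to compound 2 (1.02 log units; beyond the scatter). It also falls within the group carried by the sulfonyl sulfur, and it shows that changes there can move the number strongly in this assay. Going by the values given here, no measured compound carries the new group, so this guide is weak. Compound 2, at 8310 nM, sits at the top of the measured numbers, so a moderate move towards lower numbers is expected. The expected change is a 3.3-fold lower number from compound 2 to compound 3 (0.52 log units; beyond the scatter). For compound 3 the estimated value is 2500 nM, with an expected range from 600 nM to 10000 nM.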

Compound 3, half-maximal inhibitory concentration: 850 nM
The estimate for compound 3 lay 2.9-fold (0.47 log units) above the measured number, and the stated range covers the measured number.
By their numbers in this assay, from the lowest: compounds 1 and 3 (each within the scatter of the next); then compound 2.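

In this assay, 4-(ethoxycarbonyl)phenyl and 2-bromophenyl on the sulfonyl sulfur give very different numbers (a 9.8-fold lower number from compound 2 to compound 3 (0.99 log units; beyond the scatter)). The weak number of compound 2 is not shared by every replacement of the 2-methylphenyl group of compound 1. Compound 3 and compound 1 cannot be told apart (a 1.1-fold higher number from compound 1 to compound 3 (0.03 log units; within the scatter)), which shows that this position tolerates 4-(ethoxycarbonyl)phenyl, with its 11 heavy atoms and 2 hydrogen-bond acceptors, without any loss beyond the scatter. Nothing available explains why compound 2 stands apart from the other two.

The compounds shown leave open whether a carboxylic acid in place of the ethoxycarbonyl group would keep this number. They also leave open how an amine on the same aromatic ring would behave.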